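The source may report more compounds than this note shows. Statements on the series, on what has been measured and on what is new or still open speak of the compounds shown alone.

Measured so far:
- compound 1 `O=C(Nc1ccc(Sc2nc3ccccc3s2)c(Cl)c1)c1cccc(Br)c1O`: 6900 nM
- compound 2 `COc1c(Br)cccc1C(=O)Nc1ccc(Sc2nc3ccccc3s2)cc1`: > 100000 nM
- compound 3 `O=C(Nc1ccc(Sc2nc3ccccc3s2)cc1)c1ccccc1O`: > 100000 nM

In an assay for inhibition of HSP60/HSP10 (Homo sapiens), with a stated time of 60 min (a higher number here means a weaker inhibitor, a lower number a stronger inhibitor), compound 1 gives 6900 nM. For compound 2 the value in this assay is only a limit of the assay, > 100000 nM. For compound 3 the value is likewise only a limit, > 100000 nM, so compound 3 stands at the edge of what this assay reports rather than at a number. For the measured compounds named here, the one measured step that touches compound 3, a step that the two limits leave unreadable from compound 2 to compound 3, is hemmed in by the limit of > 100000 nM in this assay, at which 2 of the 3 values shown sit, and gives no readable size.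

Compound 4 `O=C(Nc1ccc(Sc2nc3ccccc3s2)cc1)c1cccc(Br)c1O` is not yet measured. It differs from compound 3 by bromo in place of hydrogen on an aromatic carbon, turning 2-hydroxyphenyl into 3-bromo-2-hydroxyphenyl. Going by the values given here, no measured step reports this exact change on this core. Among the compounds with values here, compound 1 is the only compound carrying the same 3-bromo-2-hydroxyphenyl group, and it differs from compound 4 in a second place. In this assay compound 1 gives 6900 nM. Since compound 3 sits at a limit, the step of an at least 5.0-fold lower number from compound 3 to compound 4 (0.69 log units; beyond the scatter) is expected to bring compound 4 into the measurable range, but its size cannot be read from the data. Compound 4 is therefore estimated at 20000 nM, within 5000 nM to 100000 nM.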

Compound 4, half-maximal inhibitory concentration: 26000 nM
Beside the measured number, compound 4's estimate is 1.3-fold (0.11 log units) below it, within the range that was stated.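

In this assay, bromo on the aromatic carbon ortho to a hydroxy group gives an at least 3.8-fold lower number from compound 3 to compound 4 (0.58 log units; beyond the scatter), so this position on the 2-hydroxyphenyl group can change the read-out on the shared core even without the chloro group of compound 1. With that bromo in place, the free hydroxy group also matters: hydrogen in place of methyl on the oxygen gives an at least 3.8-fold lower number from compound 2 to compound 4 (0.58 log units; beyond the scatter). The bromo group alone does not account for all of the strength of compound 1, since hydrogen in place of chloro gives a 3.8-fold higher number from compound 1 to compound 4 (0.58 log units; beyond the scatter), a change in a second place on the core that acts in the same direction as the bromo group.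

Compound 2 and compound 3 are held only by a limit, so the first two steps give only a minimum size and the step between these two compounds cannot be read: the limit of > 100000 nM in this assay, at which 2 of the 4 values shown sit. Going by these compounds, it remains open whether an amine or a carboxylic acid in place of the bromo group would keep the number in the measurable range, and whether the chloro step holds on a core without the bromo group.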